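The source may hold more compounds than are shown below. What is called first, only, known or untested is meant among the compounds shown, and "the series" means these compounds.

In a functional assay on MCF7 cells (Homo sapiens) for antiproliferative activity, read by MTT assay, with a stated time of 24 h (a lower number here means a stronger inhibitor, a higher number a weaker inhibitor), compound 1 `CCn1c(C(=O)N[C@H](C)C(=O)OC)ccc1C(CC)(CC)c1ccc(OCS(=O)(=O)c2ccccc2)c(C)c1` reads > 50000 nM, which is a limit of the assay and not a number. Compound 2 `CCN(CC)CCNC(=O)c1ccc(C(CC)(CC)c2ccc(OCS(=O)(=O)c3ccccc3)c(C)c2)n1CC` gives 4680 nM. Compound 3 `CCn1c(C(=O)N[C@@H](C)C(=O)O)ccc1C(CC)(CC)c1ccc(OCS(=O)(=O)c2ccccc2)c(C)c1` gives 35500 nM, the higher of the two true numbers, with a 7.6-fold higher number from compound 2 to compound 3 (0.88 log units; beyond the scatter) as the gap to its nearest neighbour.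

Compound 4 `CCn1c(C(=O)NCC(=O)O)ccc1C(CC)(CC)c1ccc(OCS(=O)(=O)c2ccccc2)c(C)c1` differs by hydrogen in place of methyl on a saturated chain carbon bound to an amide-type nitrogen and a carbonyl carbon, so 1-carboxyethyl becomes carboxymethyl.

Going by the values given here, no measured step isolates this methyl. The closest steps, an at least 1.4-fold lower number from compound 1 to compound 3 (0.14 log units; that floor lies within the scatter) and an at least 10-fold lower number from compound 1 to compound 2 (1.02 log units; beyond the scatter), each replace the whole group on the amide-type nitrogen. Only the swap to 2-(diethylamino)ethyl moves the number clearly. Compound 4 keeps the carboxy end of compound 3 at 35500 nM, so no change beyond the scatter is expected in this assay, in either direction. The estimated step is a 1.1-fold lower number from compound 3 to compound 4 (0.03 log units; within the scatter). For compound 4 the expected value is 33000 nM, with an estimated range of 15000 nM to 50000 nM.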

Compound 4, half-maximal inhibitory concentration: 33100 nM
The estimate for compound 4 lay 1.0-fold (0.00 log units) below the measured number; low and high end bracket the measured number.
By their numbers in this assay, from the lowest: compound 2; then compounds 4 and 3 (each within the scatter of the next). At a limit, above all of these: compound 1.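

In this assay, hydrogen in place of methyl on a saturated chain carbon bound to an amide-type nitrogen and a carbonyl carbon gives a 1.1-fold lower number from compound 3 to compound 4 (0.03 log units; within the scatter). The gap to the 2-(diethylamino)ethyl amide remains with either carboxy group, with a 7.1-fold higher number from compound 2 to compound 4 (0.85 log units; beyond the scatter) alongside a 7.6-fold higher number from compound 2 to compound 3 (0.88 log units; beyond the scatter). Compound 1 reads > 50000 nM, which is a limit and not a number: the limit of > 50000 nM in this assay, at which 1 of the 4 values shown sits. Read against that limit, the step gives only a floor: an at least 1.5-fold lower number from compound 1 to compound 4 (0.17 log units; that floor lies within the scatter).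

The compounds shown do not tell whether a longer chain between the amide-type nitrogen and the carboxylic acid would move the number in this assay. Going by these compounds, it also stays open whether a primary amine or a pyrrolidine in place of the diethylamino end would keep the lower number of compound 2.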